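The source may report more compounds than this note shows. Statements on the series, on what has been measured and on what is new or still open speak of the compounds shown alone.

Measured so far in a functional assay on A549 cells (Homo sapiens) for inhibition, read by CCK-8 assay, with a stated time of 72 h, tested at 10 uM; on this read-out higher numbers stand for more inhibition of growth at the one concentration tested and lower numbers for less inhibition of growth:

- compound 1 `CN(C)C(=O)c1cc2cnc(Nc3ccc(NC(=O)C4(C(=O)Nc5ccccc5)CC4)cc3)nc2n1C1CCCC1` gives 88.8%
- compound 2 `CN(C)C(=O)c1cc2cnc(Nc3ccc(NC(=O)C4(C(=O)Nc5ccccc5F)CC4)cc3)nc2n1C1CCCC1` gives 88.6%
- compound 3 `COC(=O)c1cccc(NC(=O)C2(C(=O)Nc3ccc(Nc4ncc5cc(C(=O)N(C)C)n(C6CCCC6)c5n4)cc3)CC2)c1` gives 91%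

Compound 3 carries the highest of the three numbers, but the steps of a number 2.2 percentage points higher from compound 1 to compound 3 (within the scatter) and a number 2.4 percentage points higher from compound 2 to compound 3 (within the scatter) are both within the scatter, so the three compounds cannot be ordered on these data.

Compound 4 `CN(C)C(=O)c1cc2cnc(Nc3ccc(NC(=O)C4(C(=O)Nc5ccc(F)cc5)CC4)cc3)nc2n1C1CCCC1` is the next member. Relative to compound 3 the change is 4-fluorophenyl in place of 3-(methoxycarbonyl)phenyl on an amide-type nitrogen. Among the measured compounds shown here, three measured steps bear on it. For the measured compounds named here, the step of a number 2.4 percentage points higher from compound 2 to compound 3 (within the scatter) is the closest precedent, exchanging one substituted phenyl on the same amide-type nitrogen for another, and it is within the scatter. The steps of a number 0.2 percentage points lower from compound 1 to compound 2 (within the scatter) and a number 2.2 percentage points higher from compound 1 to compound 3 (within the scatter) show that adding fluoro or methoxycarbonyl to that phenyl also stays within the scatter. Nothing in this set shows a substituent on this phenyl moving the read-out beyond the scatter, so no step beyond it is expected here.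

Compound 4 is therefore estimated at 88.5%, with a range of 80% to 95%, which means an expected step of a number 2.5 percentage points lower from compound 3 to compound 4 (within the scatter).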

Compound 4, percent growth inhibition at one concentration: 102%
Compound 4: middle estimate off by 13.5 percentage points, on the low side; the whole stated range lies below it.
By their numbers in this assay, from the lowest: compounds 2, 1 and 3 (each within the scatter of the next); then compound 4.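

On the amide-type nitrogen, in this assay, a substituent on the phenyl can move the read-out beyond the scatter: 4-fluorophenyl gives a number 13.2 percentage points higher from compound 1 to compound 4 (beyond the scatter) against plain phenyl, and a number 11 percentage points higher from compound 3 to compound 4 (beyond the scatter) against 3-(methoxycarbonyl)phenyl. The place of the fluoro on the ring counts on these numbers, as exchanging 2-fluorophenyl for 4-fluorophenyl gives a number 13.4 percentage points higher from compound 2 to compound 4 (beyond the scatter), whereas compound 1 and compound 2 lie within the scatter of each other. Nothing available explains this gain.

Open, from the compounds shown here alone, is whether the gain belongs to fluoro itself or to any group at that ring position, which 4-chlorophenyl or 4-methoxyphenyl on the same nitrogen would test. Also open, going by these compounds, is how 3-fluorophenyl would compare with the 2-fluorophenyl and 4-fluorophenyl pair.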